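The source may hold more compounds than are shown below. What is called first, only, known or untested is meant among the compounds shown, and "the series" means these compounds.

In a functional assay on EOL1 cells (Homo sapiens) for inhibition, read by fluorescence, with a stated time of 72 h (a lower number here means a stronger inhibitor of growth, a higher number a weaker inhibitor of growth), compound 1 `CCCCn1cnc2c(NCc3cccc(Cl)c3)nc(N[C@H]3CC[C@H](N)CC3)nc21` gives 350 nM, compound 2 `CCCCn1cnc2c(Nc3cc(OC)cc(OC)c3)nc(N[C@H]3CC[C@H](N)CC3)nc21` gives 370 nM and compound 3 `CCCCn1cnc2c(Nc3cccc(Cl)c3)nc(N[C@H]3CC[C@H](N)CC3)nc21` gives 160 nM, the lowest of the three numbers. Compound 4 `CCCCn1cnc2c(Nc3ccccc3)nc(N[C@H]3CC[C@H](N)CC3)nc21` differs from compound 3 at one place: hydrogen in place of chloro on an aromatic carbon. Within the data shown here, no measured step removes a chloro alone. The closest evidence is a 2.3-fold lower number from compound 2 to compound 3 (0.36 log units; beyond the scatter) and a 2.2-fold lower number from compound 1 to compound 3 (0.34 log units; beyond the scatter), both modest, while a 1.1-fold higher number from compound 1 to compound 2 (0.02 log units; within the scatter) stays within the scatter. A modest rise is therefore expected in this assay, with the expected change being a 1.6-fold higher number from compound 3 to compound 4 (0.19 log units; within the scatter). For compound 4 the estimate is 250 nM, within an expected range of 110 nM to 550 nM.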

Compound 4, concentration for 50% growth inhibition: 20 nM
Compound 4: middle estimate off by 13-fold (1.10 log units), on the high side; measured number outside the range, below it.
By their numbers in this assay, from the lowest: compound 4; then compound 3; then compounds 1 and 2 (each within the scatter of the next).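

In this assay, among these compounds, the chloro on the 3-chlorophenyl group proves far from neutral: the step to plain phenyl is an 8.0-fold lower number from compound 3 to compound 4 (0.90 log units; beyond the scatter), much larger than any step among the earlier compounds. Phenyl also stands clear of the two other groups on that nitrogen, with a 19-fold lower number from compound 2 to compound 4 (1.27 log units; beyond the scatter) and an 18-fold lower number from compound 1 to compound 4 (1.24 log units; beyond the scatter). No measurement at hand accounts for the size of these steps.

Going by these compounds, whether a fluoro, a methyl or a methoxy on that aromatic carbon would keep the number close to that of compound 4 stays open. So does whether an unsubstituted benzyl group would follow the same course.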